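The compounds below may be only part of what the source reports. "The series", "measured", "known", "first", "only" and "open" are said of these compounds alone.

Measured compounds:
compound 1 `Oc1ccc(-c2cc(-c3ccccc3O)cc(-c3cccc(O)c3)n2)cc1`: 4850 nM
compound 2 `Oc1ccccc1-c1cc(-c2ccccc2O)nc(-c2ccccc2O)c1`: 2180 nM
compound 3 `Oc1ccc(-c2cc(-c3ccc(O)cc3)nc(-c3cccc(O)c3)c2)cc1`: 3520 nM

All three were tested in a functional assay on HCT-15 cells (Homo sapiens) for cytotoxicity, read by CCK-8 assay, with a stated time of 4 days; a lower number here means a stronger inhibitor, a higher number a weaker inhibitor. Compound 1 and compound 3 share a core and differ in one place: 4-hydroxyphenyl in place of 2-hydroxyphenyl on an aromatic carbon. That change gave a 1.4-fold lower number from compound 1 to compound 3 (0.14 log units; within the scatter). Compound 2 stands on a different core; the difference between its core and that of compound 1 is not broken down here. Its value lies within the scatter of compound 3, while compound 1 gives a number beyond the scatter above it.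

Compound 4 `Oc1ccc(-c2cc(-c3ccccc3O)nc(-c3ccccc3O)c2)cc1` is not yet measured. It differs from compound 2 by 4-hydroxyphenyl in place of 2-hydroxyphenyl on an aromatic carbon. For the measured compounds named here, this is the same kind of change as the one from compound 1 to compound 3, not the same one: in compound 4 the site is meta to two 2-hydroxyphenyl groups, whereas in compound 3 it is meta to a 3-hydroxyphenyl group and meta to a 4-hydroxyphenyl group. The expectation for the step rests on compound 3, because a 1.4-fold lower number from compound 1 to compound 3 (0.14 log units; within the scatter) stayed within the scatter. A step of a 1.3-fold lower number from compound 2 to compound 4 (0.11 log units; within the scatter) is expected in this assay. For compound 4 the estimate is 1700 nM, expected between 800 nM and 4000 nM.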

Compound 4, half-maximal inhibitory concentration: > 50000 nM
Compound 4: a limit, no number; the forecaster's own chance of this, stated with the estimate: 0%; middle value at least 29-fold (1.46 log units) away from the limit.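

Compound 4 gives > 50000 nM in this assay, which is a limit of the assay and not a number. Going by these compounds, putting 4-hydroxyphenyl in place of 2-hydroxyphenyl on the core of compound 2 gave an at least 22-fold higher number from compound 2 to compound 4 (1.36 log units; beyond the scatter), so this change cannot be carried as a fixed step from one core to another, and the two steps differ: the same change on two cores in this assay, a 1.4-fold lower number (0.14 log units; within the scatter) from compound 1 to compound 3 and an at least 22-fold higher number (1.36 log units; beyond the scatter) from compound 2 to compound 4, at least 31-fold (1.49 log units) apart, beyond the scatter of two such steps Two pairs do not show which difference between the cores goes with the divergence, and the full size of the step on the core of compound 2 remains unknown.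

All the compounds shown carry only hydroxyphenyl groups, so it remains open whether a methoxy group or an amine in place of the hydroxyl would follow the step seen with compound 1 and compound 3 or the one seen with compound 2 and compound 4. The same change on a third core would show whether either step is the more usual one.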